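The source may report more compounds than this note shows. Statements on the series, on what has been measured and on what is new or still open speak of the compounds shown alone.

Values in a functional assay on MDA-MB-435 cells (Homo sapiens) for antiproliferative activity, read by MTT assay, with a stated time of 5 days; on this read-out lower numbers stand for stronger inhibition and higher numbers for weaker inhibition:
- compound 1 `COc1cc[nH]c1/C=C1\C(=O)Nc2ccc([N+](=O)[O-])cc21`: 7460 nM
- compound 2 `COc1cc[nH]c1/C=C1\C(=O)Nc2ccc([N+](=O)[O-])c(-n3ccnc3)c21`: > 30000 nM
- compound 3 `COc1cc[nH]c1/C=C1\C(=O)Nc2ccc(F)cc21`: > 30000 nM

Compound 2 gives no actual number, only a limit: it stands at the limit of > 30000 nM in this assay, at which 2 of the 3 values shown sit. Compound 3 is also reported only as a limit, > 30000 nM.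

The next compound, compound 4 `COc1cc[nH]c1/C=C1\C(=O)Nc2ccc([N+](=O)[O-])c(N[C@H]3CC[C@H](O)C3)c21`, changes compound 2 at one place: (3-hydroxycyclopentyl)amino in place of 1H-imidazol-1-yl on an aromatic carbon. The new group sits on the aromatic carbon ortho to a nitro group.

The most relevant measurement is an at least 4.0-fold higher number from compound 1 to compound 2 (0.60 log units; beyond the scatter), where 1H-imidazol-1-yl replaces hydrogen at this same place. The other measured change is an at least 4.0-fold higher number from compound 1 to compound 3 (0.60 log units; beyond the scatter), with fluoro in place of nitro. Compound 4 keeps the nitro group, so that step bears on it only weakly.

Within the data shown here, with 1H-imidazol-1-yl gone, some return toward compound 1 at 7460 nM can be expected, although no measured compound carries the new group. The expected change is modest, toward stronger inhibition: an at least 3.3-fold lower number from compound 2 to compound 4 (0.52 log units; beyond the scatter). The estimate for compound 4 is 9000 nM, with an expected range from 2000 nM to 30000 nM.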

Compound 4, half-maximal inhibitory concentration: 1000 nM
Beside the measured number, compound 4's estimate is 9.0-fold (0.95 log units) above it; the whole stated range lies above it.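

In this assay, placing (3-hydroxycyclopentyl)amino on this aromatic carbon gives a 7.5-fold lower number from compound 1 to compound 4 (0.87 log units; beyond the scatter), so the position can carry a substituent with a gain in inhibition, which compound 2 alone gave no sign of. Exchanging the 1H-imidazol-1-yl for the same group gives an at least 30-fold lower number from compound 2 to compound 4 (1.47 log units; beyond the scatter), so the identity of the group at this position matters, not merely the presence of one. Compound 2 is reported only as a limit: the limit of > 30000 nM in this assay, at which 2 of the 4 values shown sit.

The compounds shown do not tell which part of the new group goes with the gain, the hydroxyl, the amino nitrogen or the cyclopentyl ring, or whether its two defined stereocentres matter. A plain cyclopentylamino group without the hydroxyl, or the opposite stereoisomer of the same group, would separate these parts.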